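The compounds below may be only part of what the source reports. "The series", "measured", "known", "first", "only" and "open" are said of these compounds alone.

In an assay on membranes from brain for displacement of a labelled ligand from Neuronal acetylcholine receptor; alpha4/beta2 (Rattus norvegicus) (on this read-out lower numbers stand for stronger inhibition and higher numbers for weaker inhibition), compound 3 `CC(C)Cc1cncc(OC[C@@H]2CCCN2C)c1` gives 0.21 nM. Among the three compounds measured so far it stands second highest. Its nearest neighbour is compound 2 `CCCCc1cncc(OC[C@@H]2CCCN2C)c1`, which in this assay gives 0.16 nM; the gap between them, a 1.3-fold higher number from compound 2 to compound 3 (0.12 log units; within the scatter), lies within the scatter. Furthest from it is compound 1 `CN1CCC[C@H]1COc1cncc(C(F)(F)F)c1`, which in this assay gives 1.83 nM; the step of an 8.7-fold lower number from compound 1 to compound 3 (0.94 log units; beyond the scatter) is beyond the scatter, as is an 11-fold lower number from compound 1 to compound 2 (1.06 log units; beyond the scatter).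

Compound 4 `CCCCCCc1cncc(OC[C@@H]2CCCN2C)c1` has not yet been measured. It differs from compound 3 in one place: pentyl in place of isopropyl on a saturated chain carbon bound to an aromatic carbon. The measured step that bears most directly on this change is a 1.3-fold higher number from compound 2 to compound 3 (0.12 log units; within the scatter), where the saturated chain bound to the aromatic carbon was reshaped and the number stayed within the scatter. The two steps from compound 1 show only that a saturated chain in place of trifluoromethyl gave a much lower number. The step to compound 4 is therefore expected to stay within the scatter: a 1.7-fold higher number from compound 3 to compound 4 (0.22 log units; within the scatter). The estimate for compound 4 in this assay is 0.35 nM, with a range from 0.1 nM to 1.2 nM.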

Compound 4, inhibition constant: 0.32 nM
Compound 4: middle estimate off by 1.1-fold (0.04 log units), on the high side; the range from low to high includes it.
By their numbers in this assay, from the lowest: compounds 2, 3 and 4 (each within the scatter of the next); then compound 1.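

In this assay, among these compounds, the earlier compounds covered only butyl and isobutyl at this position, and the hexyl of compound 4 now extends the series. Pentyl in place of isopropyl on a saturated chain carbon bound to an aromatic carbon gives a 1.5-fold higher number from compound 3 to compound 4 (0.18 log units; within the scatter) and ethyl in place of hydrogen, four bonds along the chain from an aromatic carbon, gives a 2.0-fold higher number from compound 2 to compound 4 (0.30 log units; within the scatter) so neither change moves the number beyond the scatter. Swapping the trifluoromethyl for the hexyl chain still gives a 5.7-fold lower number from compound 1 to compound 4 (0.76 log units; beyond the scatter) which shows that a saturated chain of this length keeps a clear separation from trifluoromethyl.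

No evidence here explains why these chains give such similar numbers. Still open, going by these compounds, is how a longer chain, or a chain ending in an amine or a carboxylic acid, would behave at this position.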